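From a pyridinyl ethenyl arm to a dimethoxyphenyl arm

A few compounds are considered here, and "the series" means these few. Any claim that something is new, unique, unknown or untested is made for them only; others in the source may bear on it.

Of the compounds shown here, three sharing a common core have been measured in an assay on isolated protein with Bile acid receptor (Homo sapiens) as the target; a lower number here means that less compound is needed, a higher number that more compound is needed for the effect. Compound 1 `COC(=O)/C=C/c1cccc(N(Cc2ccc(/C=C/c3ccccn3)cc2)C(=O)C2CCCCC2)c1` gives 309 nM, the second highest of the three numbers. Compound 2 `COC(=O)/C=C/c1cccc(N(Cc2ccc(/C=C/c3ccccn3)cc2)C(=O)C(C)C)c1` gives 310 nM, and compound 3 `COC(=O)/C=C/c1cccc(N(Cc2ccc(-c3cc(Cl)ccc3OC)cc2)C(=O)C(C)C)c1` gives 226 nM. The step of a 1.0-fold higher number from compound 1 to compound 2 (0.00 log units; within the scatter) and the step of a 1.4-fold lower number from compound 2 to compound 3 (0.14 log units; within the scatter) both stay within the scatter, so none of the three can be set apart from the others.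

Compound 4 `COC(=O)/C=C/c1cccc(N(Cc2ccc(-c3c(OC)cccc3OC)cc2)C(=O)C2CCCCC2)c1` has not yet been measured. It differs from compound 1 in one place: 2,6-dimethoxyphenyl in place of 2-(pyridin-2-yl)ethenyl on an aromatic carbon. The change sits on an aromatic carbon of a six-membered aromatic ring of carbon only.

The measured step that bears most on this change is a 1.4-fold lower number from compound 2 to compound 3 (0.14 log units; within the scatter), where the same 2-(pyridin-2-yl)ethenyl group gave way to a 5-chloro-2-methoxyphenyl group on an aromatic carbon, and that step lay within the scatter. Among the compounds with values here, the 2,6-dimethoxyphenyl group entering here is not the same group, so no measured pair covers it exactly. On the evidence of compound 3 and its step of a 1.4-fold lower number from compound 2 to compound 3 (0.14 log units; within the scatter), compound 4 is expected to give a number close to that of compound 1, with a step of a 1.2-fold lower number from compound 1 to compound 4 (0.07 log units; within the scatter) that is expected to stay within the scatter. The estimate for compound 4 in this assay is 260 nM, in a range from 100 nM to 700 nM.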

Compound 4, half-maximal effective concentration: 77 nM
The estimate for compound 4 lay 3.4-fold (0.53 log units) above the measured number; the whole stated range lies above it.
By their numbers in this assay, from the lowest: compound 4; then compounds 3, 1 and 2 (each within the scatter of the next).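

In this assay the change from 2-(pyridin-2-yl)ethenyl to 2,6-dimethoxyphenyl gives a 4.0-fold lower number from compound 1 to compound 4 (0.60 log units; beyond the scatter) and is the only step among these compounds to pass beyond the scatter, which shows that the number does respond to what sits on this aromatic carbon, para to a large group. The other change at this position, with 5-chloro-2-methoxyphenyl entering, gave a 1.4-fold lower number from compound 2 to compound 3 (0.14 log units; within the scatter) and so stayed within the scatter; replacing the 2-(pyridin-2-yl)ethenyl group with a substituted phenyl group therefore did not by itself move the number beyond the scatter in every case, although these two steps differ both in the entering group and in the group on the carbonyl. The data shown offer no explanation for the size of the new step.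

On these data alone, the 2,6-dimethoxyphenyl group appears here only with cyclohexyl on the carbonyl, so it remains open whether the step would be the same with isopropyl there. Also open, as far as these compounds go, is what a plain phenyl or a 2,6-dimethylphenyl group would give at this position, and what a carboxylic acid would give in place of the methyl ester.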